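The compounds below may be only part of what the source reports. "The series", "measured", "known", "first", "only" and "open" are said of these compounds alone.

Working notes on the series. The shared core carries an aryl group on the five-membered ring and a halogenated phenyl on the lactam nitrogen. Compound 1 `O=C1CC(c2nc(-c3cccc(F)c3)no2)CN1c1ccc(Cl)cc1` gives 630 nM in an in vitro functional assay on HEK293-A cells for positive allosteric modulation of metabotropic glutamate receptor 5 (Homo sapiens), read by FLIPR and calcium flux; a higher number here means that more compound is needed for the effect, a lower number that less compound is needed. Among the measured compounds shown here, compound 3 `COc1cccc(-c2noc(C3CC(=O)N(c4ccc(Cl)cc4)C3)n2)c1` gives 4800 nM in this assay; this is the higher of the two numbers measured, and the single step leading to it is a 7.6-fold higher number from compound 1 to compound 3 (0.88 log units; beyond the scatter). Compound 2 `Cc1cccc(-c2noc(C3CC(=O)N(c4ccc(F)cc4)C3)n2)n1` reaches only > 10000 nM in this assay, which is a limit of the assay and not a number.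

Compound 4 `Cc1cccc(-c2noc(C3CC(=O)N(c4ccc(Cl)cc4)C3)n2)n1` differs from compound 3 by 6-methylpyridin-2-yl in place of 3-methoxyphenyl on an aromatic carbon. For the measured compounds named here, no measured step covers this exchange. Going by the values given here, the one step measured, a 7.6-fold higher number from compound 1 to compound 3 (0.88 log units; beyond the scatter), concerns a different substituent on the same aryl group and shows only that changes there shift the number beyond the scatter. Among the compounds with values here, compound 2 carries the same 6-methylpyridin-2-yl group as compound 4 but differs as well in the group on the lactam nitrogen, so it offers no direct step; it does sit at the limit of > 10000 nM in this assay, at which 1 of the 3 values shown sits. Because compound 2 shows > 10000 nM, the expected step for compound 4 is upward, a 1.9-fold higher number from compound 3 to compound 4 (0.27 log units; within the scatter), and a limit rather than a number is roughly an even chance. Compound 4 is estimated at 9000 nM, within 3000 nM to 30000 nM.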

Compound 4, half-maximal effective concentration: > 10000 nM
Compound 4 gave a limit, no number; the forecaster's own chance of this, stated with the estimate: 50%; middle value at least 1.1-fold (0.04 log units) from the limit.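

Replacing 3-methoxyphenyl with 6-methylpyridin-2-yl on the aromatic carbon between two ring nitrogen atoms gives an at least 2.0-fold higher number from compound 3 to compound 4 (0.31 log units; beyond the scatter) in this assay, so this position responds to a change of the whole aryl group and not only to a change of its substituent. Replacing the 3-fluorophenyl of compound 1 in the same way gives a wider span, an at least 15-fold higher number from compound 1 to compound 4 (1.20 log units; beyond the scatter), and both steps rest on a limit of the assay, not on a number. The step between compound 2 and compound 4, chloro in place of fluoro on the lactam-bound phenyl, cannot be read, as both are limits, but with either halogen the 6-methylpyridin-2-yl group ends at the same limit: the limit of > 10000 nM in this assay, at which 2 of the 4 values shown sit.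

Compound 4 changes the ring atom and the methyl-bearing substituent together, so the compounds shown do not separate the contribution of the pyridine nitrogen from that of the methyl group. Also open, from the compounds shown here alone, is how a nitrile, a trifluoromethyl group or an unsubstituted pyridine ring in this place would read in this assay.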